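A few compounds are considered here, and "the series" means these few. Any claim that something is new, unique, unknown or untested is made for them only; others in the source may bear on it.

In an assay on HeLa cells for inhibition of sphingosine-1-phosphate transporter SPNS2 (Mus musculus), read by LC-MS, tested at 2 uM (a higher number here means more inhibition at the concentration tested (going by the name of the read-out), a lower number less inhibition), compound 1 `CCCCCCCCCCc1ccc(-c2noc(CCCN)n2)cc1` gives 67%, compound 2 `CCCCCCCCCCc1ccc(-c2noc(CCCN(C)C)n2)cc1` gives 8%, and compound 3 `CCCCCCCCCCc1ccc(-c2noc(C3CCNC3)n2)cc1` gives 26%, the second highest of the three numbers. Putting a pyrrolidin-3-yl ring in place of the chain gave a number 41 percentage points lower from compound 1 to compound 3 (beyond the scatter), dimethylamino in place of amino gave a number 59 percentage points lower from compound 1 to compound 2 (beyond the scatter), and between the two compounds with the lower numbers the step was a number 18 percentage points higher from compound 2 to compound 3 (beyond the scatter). Compound 4 `CCCCCCCCCCc1ccc(-c2noc([C@@H]3CCCN3)n2)cc1` differs from compound 3 in one way: pyrrolidin-2-yl in place of pyrrolidin-3-yl on an aromatic carbon. Going by the values given here, no measured step shifts the nitrogen within a ring, so the precedent is only indirect, and the expected step of a number 4 percentage points higher from compound 3 to compound 4 (within the scatter) is one that stays within the scatter. Compound 4 is therefore estimated at 30%, with a range from 10% to 55%.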

Compound 4, a percentage reported as inhibition, at one concentration (the size of the read-out at that concentration, not a potency): 21%
Estimate against measurement, compound 4: 9 percentage points above; measured number inside the range.
By their numbers in this assay, from the lowest: compound 2; then compounds 4 and 3 (each within the scatter of the next); then compound 1.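

In this assay, changing pyrrolidin-3-yl to pyrrolidin-2-yl on this aromatic carbon gives a number 5 percentage points lower from compound 3 to compound 4 (within the scatter), so shifting the ring nitrogen's place does not separate these two rings here. Compound 4 stands clear of both open-chain compounds, with a number 13 percentage points higher from compound 2 to compound 4 (beyond the scatter) and a number 46 percentage points lower from compound 1 to compound 4 (beyond the scatter), so a second ring of this kind also stays well short of the primary amine chain. Nothing available explains these numbers. Still open, going by these compounds, is whether the mirror-image form of the pyrrolidin-2-yl ring would read the same. Also open, on these data alone, is whether a piperidine ring or a longer primary amine chain on this carbon would come closer to compound 1.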